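The compounds below may be only part of what the source reports. "The series", "measured", "known", "first", "only" and "open" are said of these compounds alone.

Two pairs of compounds share the same substituents and differ only in the core. Compound 1, whose structure is `O=C(N1CCC=C[C@@H]1COCc1ccccc1)n1cc(-c2ccc(-c3ccccc3)cc2)nn1`, and compound 2, whose structure is `O=C(N1CCC=C[C@@H]1COCc1ccccc1)n1cc(-c2ccc(Br)cc2)nn1`, both carry the first core. In an assay on HEK293 cells for inhibition of Monoacylglycerol lipase ABHD6 (Homo sapiens), read by fluorescence (a lower number here means a stronger inhibitor, a higher number a weaker inhibitor), compound 1 gives 12.6 nM. In this assay compound 2 gives 15.9 nM. The change from compound 2 to compound 1 is phenyl in place of bromo on an aromatic carbon, and it produced a 1.3-fold lower number from compound 2 to compound 1 (0.10 log units; within the scatter), so the two are indistinguishable here.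

Compound 3, whose structure is `O=C(N1CCC=C[C@@H]1COCc1ccccc1)n1cnc(-c2ccc(Br)cc2)c1`, carries the second core with the bromo group. The difference between the two cores is not broken down here. In this assay compound 3 gives only a limit, > 10000 nM, and no number; it sits at the limit of > 10000 nM in this assay, at which 1 of the 3 values shown sits.

Compound 4, whose structure is `O=C(N1CCC=C[C@@H]1COCc1ccccc1)n1cnc(-c2ccc(-c3ccccc3)cc2)c1`, is not yet measured. It differs from compound 3 by phenyl in place of bromo on an aromatic carbon, the same change as from compound 2 to compound 1, at the same place.

The step from compound 3 to compound 4 is expected to be a step that the limit leaves unreadable from compound 3 to compound 4, because the same change gave a 1.3-fold lower number from compound 2 to compound 1 (0.10 log units; within the scatter). Since compound 3 itself sits at a limit, compound 4 is expected most likely to return a limit as well. For compound 4 the estimated value is 15000 nM, with an expected range from 3000 nM to 60000 nM.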

Compound 4, half-maximal inhibitory concentration: > 10000 nM
Compound 4 was reported as a limit; the forecaster's own chance of this, stated with the estimate: 75%; the middle value lies beyond the limit too.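

In this assay compound 4 gives only a limit, > 10000 nM, and not a number. Compound 3 gives a limit too, so the step between compound 3 and compound 4 cannot be read: the limit of > 10000 nM in this assay, at which 2 of the 4 values shown sit.

As far as these compounds go, how far compound 3 and compound 4 each lie beyond that limit stays open, as does whether phenyl in place of bromo changes anything on the core they share.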